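Aryl hydrazone nucleosides: three analogues with level readings and a fourth

The source may hold more compounds than are shown below. What is called first, only, known or untested is meant among the compounds shown, and "the series" means these compounds.

Measured so far:
compound 1, `CC(=O)Nc1ccc(/C=N/Nc2nc(N)c3ncn([C@@H]4O[C@H](CO)[C@@H](O)[C@H]4O)c3n2)cc1` — 0%
compound 2, `COc1cc(/C=N/Nc2nc(N)c3ncn([C@@H]4O[C@H](CO)[C@@H](O)[C@H]4O)c3n2)cc(OC)c1OC` — 0%
compound 3, `Nc1nc(N/N=C/c2ccc(N(c3ccccc3)c3ccccc3)cc2)nc2c1ncn2[C@@H]1O[C@H](CO)[C@@H](O)[C@H]1O` — 0%

Of the compounds shown here, three sharing one core have been tested in an assay on CHO-K1 cells for displacement of a labelled ligand from adenosine receptor A1 (Homo sapiens), read by scintillation counting, with a stated time of 60 min, tested at 1 uM; a higher number here means more inhibition at the concentration tested (going by the name of the read-out), a lower number less inhibition. Compound 1 gives 0%, compound 2 gives 0%, and compound 3 gives 0%. Compound 1 therefore stands level with compounds 2 and 3 at the digits read; the gap to compound 2, its nearest neighbour, and to compound 3, its furthest, both fall within the usual scatter of such measurements, so no order can be drawn among the three. The aromatic group attached to the carbon with a double bond to nitrogen varies widely across these three compounds, and the inhibition read in this assay stays level across them.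

Compound 4, `Nc1nc(N/N=C/c2ccc(Cl)c(C(F)(F)F)c2)nc2c1ncn2[C@@H]1O[C@H](CO)[C@@H](O)[C@H]1O`, has not yet been tested in this assay. It differs from compound 1 in one place: 4-chloro-3-(trifluoromethyl)phenyl in place of 4-acetamidophenyl on a carbon with a double bond to nitrogen. Going by the values given here, no step between measured compounds is available to calibrate the effect of this exchange. Since three different aromatic groups at this position all give level readings, the step from compound 1 to compound 4 is expected to be a number 2 percentage points higher from compound 1 to compound 4 (within the scatter), that is, none beyond the scatter. For compound 4 the expected reading in this assay is 2%, with a likely range from -8% to 15%.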

Compound 4, a percentage reported as inhibition, at one concentration (the size of the read-out at that concentration, not a potency): 11%
Estimate against measurement, compound 4: 9 percentage points below; measured number inside the range.
By their numbers in this assay, from the lowest: compounds 1, 2 and 3 (each within the scatter of the next); then compound 4.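

Going by these compounds alone, putting 4-chloro-3-(trifluoromethyl)phenyl in place of 4-acetamidophenyl on a carbon with a double bond to nitrogen gives a number 11 percentage points higher from compound 1 to compound 4 (beyond the scatter) in this assay, the first step at this position that lies beyond the usual scatter, so the reading here can move with the group on that carbon. The step is modest, and compound 4 at 11% shows only a small inhibition at the single concentration tested, which is not a measure of potency. The exchange removes a group with a hydrogen-bond donor and acceptor and brings in one with neither, along with chlorine and fluorine, but no measurement here gives a reason for the step.

With these two groups changing as a whole, the compounds shown leave open whether the chlorine, the trifluoromethyl or the pair goes with the higher reading, which a phenyl ring carrying only chlorine or only trifluoromethyl would help to separate. Also open, on these data alone, is how the reading would respond to a ring bearing a nitrile or a carboxylic acid on this same carbon.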